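Dimethylaminoethyl chain extension across two chlorophenyl cores

The compounds below may be only part of what the source reports. "The series", "measured", "known", "first", "only" and "open" are said of these compounds alone.

Compound 1 `Cc1nn(C)c2c1C(c1cccc(Cl)c1)=NCCN2C` and compound 3 `Cc1nn(C)c2c1C(c1ccccc1Cl)=NCCN2C` are built from the same atoms joined differently; the difference between the two cores is not broken down here. In a functional assay on the whole organism for positive allosteric modulation, with Rattus norvegicus as the target (on this read-out higher numbers stand for an effect only at larger amounts of compound and lower numbers for an effect already at smaller amounts), compound 1 gives 0.63 mg/kg. Compound 3 gives 2.5 mg/kg in this assay, a higher number than compound 1. Compound 2 `Cc1nn(C)c2c1C(c1cccc(Cl)c1)=NCCN2CCCN(C)C` carries 2-(dimethylamino)ethyl in place of hydrogen on a saturated chain carbon bound to a nitrogen on an aromatic ring in a ring relative to compound 1. Compound 2 reaches only a limit of this assay, > 10 mg/kg. The step of an at least 15-fold higher number from compound 1 to compound 2 (1.20 log units; beyond the scatter) is bounded by the limit of > 10 mg/kg in this assay, at which 1 of the 3 values shown sits. Compound 4 `Cc1nn(C)c2c1C(c1ccccc1Cl)=NCCN2CCCN(C)C` carries the same change on the core of compound 3, (2-(dimethylamino)ethyl in place of hydrogen on a saturated chain carbon bound to a nitrogen on an aromatic ring in a ring), at an identically described place. For compound 4 a step of a 16-fold higher number from compound 3 to compound 4 (1.20 log units; beyond the scatter) is expected. This rests on the matching step an at least 15-fold higher number from compound 1 to compound 2 (1.20 log units; beyond the scatter), which was large, and on compound 3 already starting from 2.5 mg/kg. Compound 4 is estimated at 40 mg/kg, most likely reported only as a limit.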

Compound 4, minimum effective dose: > 10 mg/kg
Compound 4 was reported as a limit (the forecaster's own chance of this, stated with the estimate: 85%); the middle value does not contradict the limit.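

In this assay the change gives an at least 4.0-fold higher number from compound 3 to compound 4 (0.60 log units; beyond the scatter), so it moves the number the same way on both cores shown: the same change on two cores in this assay, an at least 15-fold higher number (1.20 log units; beyond the scatter) from compound 1 to compound 2 and an at least 4.0-fold higher number (0.60 log units; beyond the scatter) from compound 3 to compound 4; the limit leaves it open whether they differ

The sizes of the two steps cannot be compared, and the readings for compound 2 and compound 4 are limits, not numbers: the limit of > 10 mg/kg in this assay, at which 2 of the 4 values shown sit.

The step between those two compounds cannot be read, so once the chain is present, the 2-chlorophenyl and 3-chlorophenyl cores cannot be told apart.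

The compounds shown leave open whether the rise follows the chain or the terminal dimethylamino group. A plain propyl chain in the same place, or a shorter chain carrying the same amine, would bear on that.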